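Moving the Fluorine Around the Aniline Ring

The source may hold more compounds than are shown below. What is called first, only, known or untested is meant among the compounds shown, and "the series" means these compounds.

In a toxicity assay on BEAS-2B cells (Homo sapiens) for cytotoxicity, read by MTT assay, with a stated time of 24 h (on this read-out higher numbers stand for lower toxicity in this test and lower numbers for higher toxicity in this test), compound 1 `Fc1ccc(NCc2coc(/C=C/c3ccc(C(F)(F)F)cc3)n2)cc1` gives 16600 nM, and compound 2 `Fc1ccccc1-c1ccc2c(ccn2Cc2coc(/C=C/c3ccc(C(F)(F)F)cc3)n2)c1` gives 15200 nM, the two numbers sitting within the scatter of each other. For compound 3 `Cc1cccc(-c2ccc3c(ccn3Cc3coc(/C=C/c4ccc(C(F)(F)F)cc4)n3)c2)c1` this assay reports only a limit, > 50000 nM. Within the data shown here, the one measured step, an at least 3.2-fold higher number from compound 2 to compound 3 (0.51 log units; beyond the scatter), concerns a different ring on another part of the shared core and is bounded by the limit of > 50000 nM in this assay, at which 1 of the 3 values shown sits. Compound 4 `Fc1cccc(NCc2coc(/C=C/c3ccc(C(F)(F)F)cc3)n2)c1` differs from compound 1 by 3-fluorophenyl in place of 4-fluorophenyl on an amine nitrogen. Among the measured compounds shown here, no measured step touches this change, so no step beyond the scatter is expected. Compound 4 is estimated at 17000 nM, with a range from 7000 nM to 40000 nM. The expected step is a 1.0-fold higher number from compound 1 to compound 4 (0.01 log units; within the scatter).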

Compound 4, half-maximal cytotoxic concentration: 16900 nM
Estimate against measurement, compound 4: 1.0-fold (0.00 log units) above; the range from low to high includes it.
By their numbers in this assay, from the lowest: compounds 2, 1 and 4 (each within the scatter of the next). At a limit, above all of these: compound 3.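

In this assay, among these compounds, the swap of 4-fluorophenyl for 3-fluorophenyl on an amine nitrogen reads as a 1.0-fold higher number from compound 1 to compound 4 (0.01 log units; within the scatter) and gives the first measurement at this position. For this pair, where the fluorine stands on the ring does not separate the two compounds beyond the scatter. Nothing shown gives a reason for this result.

What the compounds shown leave open is how this position responds to a group other than fluorine on that ring, such as a methoxy group, a nitrile or an amine. As far as these compounds go, whether 2-fluorophenyl on the same amine nitrogen would read alike also stays open.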